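Swapping the Aminoethoxy Side Chain for a Diamine

The source may report more compounds than this note shows. Statements on the series, on what has been measured and on what is new or still open speak of the compounds shown alone.

Compound 1, `COc1cc(OC)c2c(=O)cc(-c3ccc(OC4CCN(C)CC4)cc3)oc2c1`, in a functional assay (Homo sapiens) for antiproliferative activity, read by resazurin assay, with a stated time of 48 h, tested at 10 uM (a higher number here means a stronger effect of the compound at the concentration tested, a lower number a weaker effect), compound 1 gives 49%.
Compound 2, `COc1cc(OC)c2c(=O)cc(-c3ccc(OCCN)cc3)oc2c1`, gives 35%.
Compound 3, `COc1cc(OC)c2c(=O)cc(-c3ccc(OCC(O)CN(C)C)cc3)oc2c1`, gives 60%.

Compound 2 stands lowest of the three measured compounds. Going from it to compound 1 reverses the step of a number 14 percentage points lower from compound 1 to compound 2 (beyond the scatter), and the step of a number 25 percentage points higher from compound 2 to compound 3 (beyond the scatter) is the larger of the two. Compound 4, `COc1cc(OC)c2c(=O)cc(-c3ccc(NCCN(C)C)cc3)oc2c1`, differs from compound 2 by (2-(dimethylamino)ethyl)amino in place of 2-aminoethoxy on an aromatic carbon.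

Among the compounds with values here, two measured steps bear on this change. In the step of a number 25 percentage points higher from compound 2 to compound 3 (beyond the scatter) a chain carrying a dimethylamino group replaced one carrying a plain amino group and the number rose modestly. In the step of a number 14 percentage points lower from compound 1 to compound 2 (beyond the scatter) the 1-methylpiperidin-4-yl group gave way to 2-aminoethyl and the number fell modestly. Both measured compounds whose side chain ends in a tertiary amine thus score higher than compound 2, whose chain ends in a primary amine. Within the data shown here, no measured compound shows an amino linker in place of the oxygen, so that part of the change has no precedent here.

Compound 4 is therefore expected to lie above compound 2 by a modest margin, at an estimated 50% with a range from 36% to 64%. The expected step is a number 15 percentage points higher from compound 2 to compound 4 (beyond the scatter).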

Compound 4, a percentage reported as inhibition, at one concentration (the size of the read-out at that concentration, not a potency): 60%
For compound 4 the middle estimate is 10 percentage points below the measured one; the range from low to high includes it.
By their numbers in this assay, from the lowest: compound 2; then compound 1; then compounds 3 and 4 (each within the scatter of the next).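

In this assay, an amino linker at this aromatic carbon is compatible with a reading as high as any seen so far: the change to (2-(dimethylamino)ethyl)amino gives a number 25 percentage points higher from compound 2 to compound 4 (beyond the scatter) and, measured against the (1-methylpiperidin-4-yl)oxy chain, a number 11 percentage points higher from compound 1 to compound 4 (beyond the scatter). The comparison with the hydroxyl-bearing ether chain gives no change at the digits printed from compound 3 to compound 4 (within the scatter), so two side chains that differ in linker atom, length and hydroxyl group cannot be told apart here, and the hydroxyl group of compound 3 is not needed to reach this level. No measurement shown here accounts for these differences.

From the compounds shown here alone, compound 4 changes the linker and the end of the chain together, so the share of each remains open: the 2-(dimethylamino)ethoxy chain, with oxygen kept and a dimethylamino end, and the (2-aminoethyl)amino chain, with the amino linker and a plain amino end, would separate the two. Also open, going by these compounds, is how far this level holds with a longer chain such as (3-(dimethylamino)propyl)amino, or with a morpholine ring at the end of the chain.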